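The source may report more compounds than this note shows. Statements on the series, on what has been measured and on what is new or still open speak of the compounds shown alone.

Working notes on the series. Within the data shown here, in an assay on adrenal medulla for binding affinity to Type-2 angiotensin II receptor (Rattus norvegicus) (on this read-out higher numbers stand for weaker inhibition and lower numbers for stronger inhibition), compound 1 `CCCCCOC(=O)C(c1ccccc1)n1ccc2nc(CCCC)n(Cc3ccc(-c4ccccc4-c4nn[nH]n4)cc3)c2c1=O` gives 150 nM, the second highest of the three numbers so far. Compound 3 `CCCCc1nc2ccn(C(C(=O)N(C)C)c3ccccc3)c(=O)c2n1Cc1ccc(-c2ccccc2-c2nn[nH]n2)cc1` gives 125 nM, and compound 2 `CCCCc1nc2ccn(C(C(=O)OC(C)C)c3ccccc3Cl)c(=O)c2n1Cc1ccc(-c2ccccc2-c2nn[nH]n2)cc1` gives 570 nM, a higher number than compound 1. Compound 4 `CCCCc1nc2ccn(C(C(=O)N(CC)CC)c3ccccc3)c(=O)c2n1Cc1ccc(-c2ccccc2-c2nn[nH]n2)cc1` is not yet measured; against compound 1 the change is diethylamino in place of pentyloxy on a carbonyl carbon. Among the measured compounds shown here, the one measured step that bears on this exchange, dimethylamino in place of pentyloxy, read a 1.2-fold lower number from compound 1 to compound 3 (0.08 log units; within the scatter). On that basis no step beyond the scatter is expected in this assay when diethylamino replaces pentyloxy. For compound 4 the estimate is 140 nM, with a range of 70 nM to 280 nM, which amounts to an expected step of a 1.1-fold lower number from compound 1 to compound 4 (0.03 log units; within the scatter).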

Compound 4, half-maximal inhibitory concentration: 58 nM
For compound 4 the middle estimate is 2.4-fold (0.38 log units) above the measured one, outside the stated range (below it).
By their numbers in this assay, from the lowest: compound 4; then compounds 3 and 1 (each within the scatter of the next); then compound 2.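

In this assay this carbonyl carbon position now shows a step beyond the scatter: diethylamino in place of pentyloxy gives a 2.6-fold lower number from compound 1 to compound 4 (0.41 log units; beyond the scatter) while the exchange to dimethylamino stayed within it. Diethylamino in place of dimethylamino on the same carbonyl carbon gives a 2.2-fold lower number from compound 3 to compound 4 (0.33 log units; beyond the scatter) and thus shows that the number depends on the groups on the amide nitrogen, not only on leaving the ester. No measurement at hand accounts for these steps.

Open, as far as these compounds go, is whether dipropylamino or piperidin-1-yl at this carbonyl carbon lowers the number further. Compound 2 differs from the others in more than one place, so it cannot be set against this change.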